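The source may report more compounds than this note shows. Statements on the series, on what has been measured and on what is new or still open speak of the compounds shown alone.

Measured so far in a functional assay on MDA-MB-231 cells (Homo sapiens) for inhibition, read by sulforhodamine B assay; on this read-out higher numbers stand for weaker inhibition and lower numbers for stronger inhibition:
Compound 1 `COC(=O)CC/C(C)=C/Cc1c(OC)c(C)c2c(c1OCC#CCN1CCN(c3ccc(O)cc3)CC1)C(=O)OC2`: > 50000 nM, a limit
Compound 2 `COC(=O)CC/C(C)=C/Cc1c(OC)c(C)c2c(c1OCC#CCN1CCC(Cc3ccccc3)CC1)C(=O)OC2`: > 50000 nM, a limit

Compound 2 has no exact number and stands at the limit of > 50000 nM in this assay, at which 2 of the 2 values shown sit. Compound 3 `COC(=O)CC/C(C)=C/Cc1c(OC)c(C)c2c(c1OCC#CCN1CCC(C(=O)OC)CC1)C(=O)OC2` carries methoxycarbonyl in place of benzyl on a saturated ring carbon. Going by the values given here, no measured pair shows this change, so the expectation rests only on the two limits. No shift beyond the usual scatter is expected in this assay, in either direction, and the estimated step of a number no higher from compound 2 to compound 3 (the limit leaves the size open) is small. For compound 3 the expected value is 50000 nM, with an estimated range from 20000 nM to 100000 nM.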

Compound 3, half-maximal inhibitory concentration: > 50000 nM
Compound 3: only a limit was reported (the forecaster's own chance of this, stated with the estimate: 80%); the middle value lies on the limit itself.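

No step can be read from compound 2 to compound 3, since both values in this assay are limits: the limit of > 50000 nM in this assay, at which 3 of the 3 values shown sit. The compounds shown leave open how strongly any of them inhibits, and whether exchanging benzyl for methoxycarbonyl changes that at all.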